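The source may hold more compounds than are shown below. What is called first, only, known or untested is meant among the compounds shown, and "the series" means these compounds.

Values in a functional assay on MHCC97H cells (Homo sapiens) for antiproliferative activity, read by MTT assay, with a stated time of 48 h; on this read-out lower numbers stand for stronger inhibition and higher numbers for weaker inhibition:
- compound 1 `COc1cc(C(=O)/C=C/c2c[nH]c3ccccc23)cc([N+](=O)[O-])c1OC`: 830 nM
- compound 2 `COc1cc(C(=O)/C=C/c2cn(C)c3ccccc23)cc(SC)c1OC`: 150 nM
- compound 3 `COc1cc(C(=O)/C=C/c2cn(C)c3ccccc23)cc(N)c1OC`: 289 nM
- compound 4 `COc1cc(C(=O)/C=C/c2cn(C)c3ccccc23)cc([N+](=O)[O-])c1OC`: not yet measured

Compound 3 at 289 nM lies within the scatter of compound 2, and its number is lower than that of compound 1, a gap beyond the scatter. The next change is nitro in place of amino on an aromatic carbon, which leads to compound 4.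

Among the compounds with values here, one measured step bears on this carbon directly: a 1.9-fold higher number from compound 2 to compound 3 (0.28 log units; within the scatter), with amino in place of methylsulfanyl. That exchange did not move the number beyond the scatter, but it involves no nitro group. Within the data shown here, compound 1 does carry nitro and gives 830 nM, yet its core differs from that of compound 4, and no measured step isolates that difference. The exchange of amino for nitro has therefore not been measured on its own.

In this assay, a small step is expected, leaning towards a higher number on the evidence of compound 1 at 830 nM. The estimated change is a 1.2-fold higher number from compound 3 to compound 4 (0.08 log units; within the scatter), so nothing beyond the scatter is expected. For compound 4 the estimate is 350 nM, with an expected range from 120 nM to 900 nM.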

Compound 4, half-maximal inhibitory concentration: 850 nM
Compound 4: the middle estimate sits 2.4-fold (0.39 log units) below what was measured, and the stated range covers the measured number.
By their numbers in this assay, from the lowest: compounds 2 and 3 (each within the scatter of the next); then compounds 1 and 4 (each within the scatter of the next).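

In this assay, the exchange of amino for nitro on this aromatic carbon can now be read on its own, as a 2.9-fold higher number from compound 3 to compound 4 (0.47 log units; beyond the scatter), and nitro in place of methylsulfanyl on the same carbon gives a 5.7-fold higher number from compound 2 to compound 4 (0.75 log units; beyond the scatter). The position is therefore not indifferent to its group: the earlier exchange between methylsulfanyl and amino (a 1.9-fold higher number from compound 2 to compound 3 (0.28 log units; within the scatter)) stayed within the scatter, whereas both steps to nitro lie beyond it, in the direction of weaker inhibition. With nitro held in place, methyl in place of hydrogen on the aromatic nitrogen gives a 1.0-fold higher number from compound 1 to compound 4 (0.01 log units; within the scatter), which is within the scatter, so compound 1 and compound 4 now read as one level and the nitrogen substituent shows no effect in this nitro pair; no measurement at hand explains why nitro raises the number on this carbon.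

The compounds shown leave open whether the same nitrogen exchange stays within the scatter when amino or methylsulfanyl occupies the carbon, since the pair covers nitro alone. They also leave open whether groups such as hydroxyl, a carboxylic acid or ethylsulfanyl on this carbon would fall with amino and methylsulfanyl or with nitro.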